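Aryl exchange on the shared core: compound 3 to compound 4

The compounds below may be only part of what the source reports. "The series", "measured", "known", "first", "only" and "open" are said of these compounds alone.

In a functional assay on A549 cells (Homo sapiens) for antiproliferative activity, read by MTT assay, with a stated time of 72 h (on this read-out lower numbers stand for stronger inhibition and higher numbers for weaker inhibition), compound 1 `COc1ccccc1-c1ccc2ncn(-c3cc(OC)c(OC)c(OC)c3)c2c1` gives 4320 nM. Compound 3 `COc1cc(-n2cnc3ccc(-c4ccc(C(F)(F)F)cc4)cc32)cc(OC)c1OC` gives 3390 nM, and a 1.3-fold lower number from compound 1 to compound 3 (0.11 log units; within the scatter) places the two within the scatter of each other. Compound 2 `COc1cc(-n2cnc3ccc(-c4ccc(C)cc4F)cc32)cc(OC)c1OC` is reported only as a limit, > 10000 nM. Compound 3 stands clear of that limit, with an at least 2.9-fold lower number from compound 2 to compound 3 (0.46 log units; beyond the scatter).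

Compound 4 `COc1cc(-n2cnc3ccc(-c4cccc([N+](=O)[O-])c4)cc32)cc(OC)c1OC` carries 3-nitrophenyl in place of 4-(trifluoromethyl)phenyl on an aromatic carbon. Three measured exchanges at this carbon bear on the change. Compound 1 and compound 3 show that one exchange can leave the number unmoved, with a 1.3-fold lower number from compound 1 to compound 3 (0.11 log units; within the scatter). Compound 2 shows that another can cost activity, with an at least 2.3-fold higher number from compound 1 to compound 2 (0.36 log units; beyond the scatter). For the measured compounds named here, no measured compound carries a nitro group, so the direction stays open, with a slight lean towards weaker inhibition. The estimate is a 1.2-fold higher number from compound 3 to compound 4 (0.07 log units; within the scatter), which is expected to stay within the scatter. For compound 4 the expected value is 4000 nM, with an estimated range of 1400 nM to 10000 nM.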

Compound 4, half-maximal inhibitory concentration: 5410 nM
The estimate for compound 4 lay 1.4-fold (0.13 log units) below the measured number; low and high end bracket the measured number.
By their numbers in this assay, from the lowest: compounds 3, 1 and 4 (each within the scatter of the next). At a limit, above all of these: compound 2.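

In this assay, a nitro-bearing ring now joins the series at this carbon, and 3-nitrophenyl stays within the scatter of both 4-(trifluoromethyl)phenyl and 2-methoxyphenyl: a 1.6-fold higher number from compound 3 to compound 4 (0.20 log units; within the scatter) and a 1.3-fold higher number from compound 1 to compound 4 (0.10 log units; within the scatter). Compound 2 is a limit and not a number, so the step to compound 4 gives only a floor, an at least 1.8-fold lower number from compound 2 to compound 4 (0.26 log units; that floor lies within the scatter), and, unlike compound 3, compound 4 is not clearly separated from it. Every aryl exchange at this carbon with a step beyond the scatter still involves that one limit: the limit of > 10000 nM in this assay, at which 1 of the 4 values shown sits.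

On these data alone, what an amine, a carboxylic acid or a longer chain on this carbon would do to the number stays open. No two compounds shown carry the same group at two places on the phenyl ring, so the effect of substituent placement also stays open.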